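This account rests on a few compounds, and the source may have more. Where it says the series, first, only, none or still open, it means among the compounds named here.

Measured compounds:
- compound 1, `Nc1nc(Cl)c2ncn(Cc3ccc(CCl)cc3)c2n1`, which in a functional assay on SK-OV-3 cells (Homo sapiens) for cytotoxicity, read by sulforhodamine B assay, with a stated time of 48 h (on this read-out lower numbers stand for higher toxicity in this test and higher numbers for lower toxicity in this test), gives 64500 nM
- compound 3, `ClCc1ccc(Cn2cnc3c(Cl)nc(Cl)nc32)cc1`, which in this assay gives 66100 nM
- compound 2, `ClCc1cccc(Cn2cnc3c(Cl)nc(Cl)nc32)c1`, for which this assay gives "not determined" (no result reported)

The two compounds with numbers, compound 3 and compound 1, are close together: the step of a 1.0-fold lower number from compound 3 to compound 1 (0.01 log units; within the scatter) corresponds to the change (amino in place of chloro on an aromatic carbon). The same change is to be made from compound 2 to compound 4, `Nc1nc(Cl)c2ncn(Cc3cccc(CCl)c3)c2n1`, and here it is described as amino in place of chloro on an aromatic carbon. The place of the change reads the same way in both pairs, so it is the same change, made on two different cores. How the core of compound 2 differs from the core of compound 3 is not broken down here; the two contain the same atoms joined differently.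

For compound 2 itself no number is known in this assay, so the step to compound 4 cannot be set against a starting value. Beside the earlier step, the step from compound 2 to compound 4 is expected to be of a similar small size, because the earlier step of a 1.0-fold lower number from compound 3 to compound 1 (0.01 log units; within the scatter) was small and the change is the same. That expectation rests on a single measured pair and on nothing else. Since compound 1 gives 64500 nM and compound 3 gives 66100 nM, compound 4 is estimated to fall near them, at 65000 nM, with a range expected from 30000 nM to 140000 nM.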

Compound 4, concentration lethal to 50% of the cells: > 100000 nM
Compound 4: a limit, no number (the forecaster's own chance of this, stated with the estimate: 20%); middle value at least 1.5-fold (0.18 log units) away from the limit.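

In this assay, compound 4 gives > 100000 nM, which is a limit and not a number. Among the compounds shown here, with no number for compound 2 either, no step from compound 2 to compound 4 can be read. The compounds shown leave open whether amino in place of chloro on an aromatic carbon changes the read-out on the core of compound 2 as little as it does on the core of compound 3.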